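The source may hold more compounds than are shown below. What is called first, only, known or untested is meant among the compounds shown, and "the series" means these compounds.

Measured compounds in a functional assay on HOP-62 cells (Homo sapiens) for cytotoxicity, read by sulforhodamine B assay, with a stated time of 48 h, tested at 0.01 uM; on this read-out lower numbers stand for a stronger effect and higher numbers for a weaker effect at the one concentration tested:
- Compound 1 `COc1cc(-c2cc(/C=C/C(=O)c3ccc(Cl)c(Cl)c3)[nH]n2)cc(OC)c1OC` gives 99%
- Compound 2 `COc1ccc(-c2cc(/C=C/C(=O)c3ccc(N)cc3)[nH]n2)cc1OC` gives 83%
- Compound 3 `COc1ccc(-c2cc(/C=C/C(=O)c3cc(OC)c(OC)c(OC)c3)[nH]n2)cc1OC` gives 92%

Compound 1 stands at the highest number of the three, which on this read-out means the weakest effect at the single concentration tested. Its nearest neighbour is compound 3, whose value lies within the usual scatter of compound 1, so no order can be drawn between these two. Compound 2 stands furthest from compound 1, and that gap lies beyond the scatter, so compound 2 shows a somewhat stronger effect than compound 1. All three numbers sit in the upper part of the scale, which means that at this concentration none of the compounds produces a large effect on the cells.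

Compound 4 `COc1ccc(C(=O)/C=C/c2cc(-c3cc(OC)c(OC)c(OC)c3)n[nH]2)cc1OC` has not yet been measured in this assay. It differs from compound 1 in one place: 3,4-dimethoxyphenyl in place of 3,4-dichlorophenyl on a carbonyl carbon. The shared core and the rest of the molecule are unchanged.

Since compound 3, which also carries methoxy groups on the ring attached to the carbonyl carbon, gives 92%, the step from compound 1 to compound 4 is expected to be small, a slight decrease at most, and is estimated at a number 6 percentage points lower from compound 1 to compound 4 (within the scatter), probably within the scatter. Compound 4 is therefore expected to give about 93%, with a range from 80% to 102%.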

Compound 4, a percentage reported as activity, at one concentration (the size of the read-out at that concentration, not a potency): 101%
Estimate against measurement, compound 4: 8 percentage points below, and the stated range covers the measured number.
By their numbers in this assay, from the lowest: compounds 2, 3, 1 and 4 (each within the scatter of the next, the first and the last beyond it).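

In this assay, among the compounds shown here, exchanging 3,4-dichlorophenyl for 3,4-dimethoxyphenyl on a carbonyl carbon gives a number 2 percentage points higher from compound 1 to compound 4 (within the scatter), the first direct reading of a change at this position, and it does not separate the two groups. The entering group carries 2 hydrogen-bond acceptors where the leaving group carries 0, yet this difference leaves no mark on the read-out that can be told from scatter at the one concentration tested. However, compound 1 gives 99% and compound 4 gives 101%, both at the weak end of the scale, so the pair shows only that neither group produces a large effect here, and nothing at hand accounts for the result.

As far as these compounds go, whether a phenyl ring bearing a carboxylic acid or a nitrile on this carbonyl carbon would produce a step beyond the scatter remains open. Also open, from the compounds shown here alone, is whether compound 1 and compound 4 would separate at a higher concentration, where a larger effect might leave more room for a difference to appear.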